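Lengthening the Amine Chain of Compound 3

The source may report more compounds than this note shows. Statements on the series, on what has been measured and on what is new or still open speak of the compounds shown alone.

In a functional assay on A549 cells (Homo sapiens) for antiproliferative activity, read by MTT assay, with a stated time of 48 h (a lower number here means a stronger inhibitor, a higher number a weaker inhibitor), compound 3 `CN(C)CCn1c(N)c(-c2nc3ccccc3n2C)c2nc(C#N)c(C#N)nc21` reads > 50000 nM, which is a limit of the assay and not a number. Compound 1 `CN(C)CCn1c(N)c(-c2nc3ccccc3[nH]2)c2nc(C#N)c(C#N)nc21` reads > 50000 nM, which is also a limit. That places compound 3 at the limit of > 50000 nM in this assay, at which 2 of the 3 values shown sit. For the measured compounds named here, the one measured step, a step that the two limits leave unreadable from compound 1 to compound 3, concerns a methyl group and not the chain, and it gives no size to build on.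

Compound 4 `CN(C)CCCCn1c(N)c(-c2nc3ccccc3n2C)c2nc(C#N)c(C#N)nc21` keeps everything in compound 3 except the chain: 2-(dimethylamino)ethyl in place of dimethylamino on a saturated chain carbon, two bonds along the chain from an aromatic nitrogen. In words, 2-(dimethylamino)ethyl replaces dimethylamino on a saturated chain carbon, two bonds along the chain from an aromatic nitrogen, which turns 2-(dimethylamino)ethyl into 4-(dimethylamino)butyl.

Going by the values given here, no measured step shows this change directly. Among the compounds with values here, the only real number comes from compound 2 `CN(C)CCCn1c(N)c(-c2nc3ccccc3s2)c2nc(C#N)c(C#N)nc21`, at 8870 nM, and it differs from compound 3 in more than one place, so it is loose guidance. Still, that value shows that a related structure can register in this assay, so a modest move towards stronger inhibition is expected, with a real chance that compound 4 also stays at the limit. The expected change is an at least 2.5-fold lower number from compound 3 to compound 4 (0.39 log units; beyond the scatter). For compound 4 the estimated value is 20000 nM, with an expected range from 5000 nM to 50000 nM.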

Compound 4, half-maximal inhibitory concentration: 6150 nM
Estimate against measurement, compound 4: 3.3-fold (0.51 log units) above, and the stated range covers the measured number.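

In this assay, putting 2-(dimethylamino)ethyl in place of dimethylamino on a saturated chain carbon, two bonds along the chain from an aromatic nitrogen, gives an at least 8.1-fold lower number from compound 3 to compound 4 (0.91 log units; beyond the scatter), which lies beyond the usual scatter. Compound 3 stands at a limit of the assay and not at a number, so this size is only a floor: the limit of > 50000 nM in this assay, at which 2 of the 4 values shown sit. The earlier compounds shown here offered only an unreadable step about a methyl group and a real number from compound 2, which differs from compound 3 in more than one place, whereas this pair ties a readable gain to the chain alone, with the rest of the structure unchanged.

On these data alone, one pair cannot give a trend with chain length, so it remains open whether a still longer chain, such as 6-(dimethylamino)hexyl, or a ring amine such as morpholine in place of dimethylamino, would move the number further. Also open, as far as these compounds go, is whether 4-(dimethylamino)butyl would have the same effect on compound 1, which carries hydrogen in place of methyl on the aromatic nitrogen.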